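Aryl swap on the shared core: expectation for compound 4

The compounds below may be only part of what the source reports. "The series", "measured", "known", "first", "only" and "open" are said of these compounds alone.

Three measured compounds share one core and differ only at two aromatic positions. Compound 1 `COc1cccc(-c2nc(SCC(=O)c3sc(-c4ccccc4)nc3C)[nH]c(=O)c2C#N)c1` gives 21.8% in a functional assay on U-87MG ATCC cells for antiproliferative activity against U-87 MG (Homo sapiens), read by MTT assay, with a stated time of 48 h, tested at 100 uM; a higher number here means a weaker effect of the compound at the concentration tested, a lower number a stronger effect. Compound 2 `Cc1nc(-c2ccccc2)sc1C(=O)CSc1nc(-c2ccc(Cl)cc2)c(C#N)c(=O)[nH]1` gives 22.5% in this assay, and compound 3 `Cc1nc(-c2ccc(Cl)cc2)sc1C(=O)CSc1nc(-c2ccc(Cl)cc2)c(C#N)c(=O)[nH]1` gives 12.8% in this assay. The two steps out of compound 2, a number 0.7 percentage points lower from compound 2 to compound 1 (within the scatter) and a number 9.7 percentage points lower from compound 2 to compound 3 (within the scatter), both stay within the scatter, so the three values are not separated by this read-out.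

Compound 4 `COc1cccc(-c2nc(SCC(=O)c3sc(-c4ccc(Cl)cc4)nc3C)[nH]c(=O)c2C#N)c1` is not yet measured. For the measured compounds named here, the change from compound 3 to compound 4, (3-methoxyphenyl in place of 4-chlorophenyl on an aromatic carbon), is the same as the one already made from compound 2 to compound 1, (3-methoxyphenyl in place of 4-chlorophenyl on an aromatic carbon), with identical surroundings at the place of change. The two cores differ by chloro in place of hydrogen on an aromatic carbon.

Because the measured instance of this change gave a number 0.7 percentage points lower from compound 2 to compound 1 (within the scatter), a step of about the same size is expected from compound 3 to compound 4 in this assay, namely a number 0.8 percentage points lower from compound 3 to compound 4 (within the scatter), within the scatter. Compound 4 is therefore estimated at 12%, with a range of 4% to 22%, resting on compound 3 at 12.8%.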

Compound 4, a percentage reported as activity, at one concentration (the size of the read-out at that concentration, not a potency): 8.54%
The estimate for compound 4 lay 3.5 percentage points above the measured number; low and high end bracket the measured number.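

In this assay, 3-methoxyphenyl in place of 4-chlorophenyl gives a number 4.3 percentage points lower from compound 3 to compound 4 (within the scatter) and carries across the two cores without a separable difference: the same change on two cores in this assay, a number 0.7 percentage points lower (within the scatter) from compound 2 to compound 1 and a number 4.3 percentage points lower (within the scatter) from compound 3 to compound 4, 3.6 percentage points apart, within the scatter of two such steps. Chloro in place of hydrogen on the aromatic carbon gives a number 13.3 percentage points lower from compound 1 to compound 4 (beyond the scatter) and is the only step here beyond the scatter, yet its size is not separated from that of the same change on the other core: the same change on two cores in this assay, a number 9.7 percentage points lower (within the scatter) from compound 2 to compound 3 and a number 13.3 percentage points lower (beyond the scatter) from compound 1 to compound 4, 3.6 percentage points apart, within the scatter of two such steps. This shows that both changes read alike on two cores at one concentration, but it gives no potency, and one pair of cores per change does not make a rule for the wider series.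

Among the aryl substituents, the compounds shown cover only chloro and methoxy, so the effect of an amine or a carboxylic acid on these rings remains open. Also open, as far as these compounds go, is how the series responds to a longer chain between the sulfur and the carbonyl, or to another group in place of the nitrile.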